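The compounds below may be only part of what the source reports. "The series", "measured", "known", "first", "only" and "open" are said of these compounds alone.

Compound 2, with the structure `COc1ccc(C2CC(c3ccc4ccccc4c3)=NN2CC=O)cc1`, gives 4120 nM in a functional assay on IMR-32 cells (Homo sapiens) for cytotoxicity, read by sulforhodamine B assay, with a stated time of 48 h (on this read-out higher numbers stand for weaker inhibition and lower numbers for stronger inhibition), and so has the lowest number of the two measured in this assay. Among the measured compounds shown here, its only neighbour is compound 1, with the structure `O=CCN1N=C(c2ccc3ccccc3c2)CC1c1ccccc1`, which in this assay gives 10000 nM; the step of a 2.4-fold lower number from compound 1 to compound 2 (0.39 log units; beyond the scatter) is the single measured step so far. Compound 3, with the structure `O=CCN1N=C(c2ccc3ccccc3c2)CC1/C=C/c1ccccc1`, differs from compound 2 by 2-phenylethenyl in place of 4-methoxyphenyl on a saturated ring carbon. For the measured compounds named here, the one measured step bears on it only indirectly: compound 3 carries neither the methoxy of compound 2 nor the bare phenyl of compound 1, so the gain seen in the step from compound 1 to compound 2 is expected to be given back, with no measured step telling how the phenylethenyl itself behaves. The number for compound 3 in this assay is therefore expected to rise modestly, by a 1.9-fold higher number from compound 2 to compound 3 (0.29 log units; within the scatter). Compound 3 is estimated at 8000 nM, within a range from 2500 nM to 25000 nM.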

Compound 3, half-maximal inhibitory concentration: 17200 nM
Compound 3: middle estimate off by 2.2-fold (0.33 log units), on the low side, and the stated range covers the measured number.
By their numbers in this assay, from the lowest: compound 2; then compounds 1 and 3 (each within the scatter of the next).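

In this assay, 2-phenylethenyl in place of 4-methoxyphenyl on the saturated ring carbon gives a 4.2-fold higher number from compound 2 to compound 3 (0.62 log units; beyond the scatter), a step beyond the scatter, so the lower number of compound 2 does not carry over to this group. Set against the plain phenyl, the same group gives a 1.7-fold higher number from compound 1 to compound 3 (0.24 log units; within the scatter), which lies within the scatter, so the added double bond outside the aromatic rings brings no change that can be told apart here, and of the three compounds only compound 2, with its methoxy, stands apart from the others. Nothing at hand accounts for these results.

The compounds shown leave open whether a methoxy on the phenyl ring of the 2-phenylethenyl group would lower the number as it does in compound 2. They also leave open how a hydroxyl or a dimethylamino group would behave in place of that methoxy.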